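Chloro in Place of Hydrogen on Compound 3

A few compounds are considered here, and "the series" means these few. Any claim that something is new, unique, unknown or untested is made for them only; others in the source may bear on it.

In a functional assay on Hs-578T cells (Homo sapiens) for inhibition, read by sulforhodamine B assay, with a stated time of 48 h (on this read-out lower numbers stand for stronger inhibition of growth and higher numbers for weaker inhibition of growth), compound 3 (`COc1cc(-c2nn(-c3cccc(NC(=O)Nc4cccc(C(F)(F)F)c4)c3)cc2-c2ccncc2)ccc1Cl`) gives 1230 nM. Compound 1 (`COc1cc(-c2nn(-c3cccc(NC(=O)Nc4cc(C(F)(F)F)cc(C(F)(F)F)c4)c3)cc2-c2ccncc2)ccc1Cl`) gives 1040 nM, and compound 2 (`COc1cc(-c2nn(-c3cccc(NC(=O)Nc4ccc(Cl)c(Cl)c4)c3)cc2-c2ccncc2)ccc1Cl`) gives 1430 nM. Compound 3 thus stands within the scatter of both of the other compounds, and the three values form a single tight group.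

Compound 4 (`COc1cc(-c2nn(-c3cccc(NC(=O)Nc4ccc(Cl)c(C(F)(F)F)c4)c3)cc2-c2ccncc2)ccc1Cl`) differs from compound 3 by chloro in place of hydrogen on an aromatic carbon, ortho to a trifluoromethyl group and para to a large group: chloro in place of hydrogen on an aromatic carbon. This turns the 3-(trifluoromethyl)phenyl into 4-chloro-3-(trifluoromethyl)phenyl.

Among the measured compounds shown here, no measured step makes exactly this change, but two steps alter the same aryl group. One is a 1.2-fold higher number from compound 1 to compound 3 (0.07 log units; within the scatter), and the other, which involves 3,4-dichlorophenyl, is a 1.2-fold lower number from compound 2 to compound 3 (0.07 log units; within the scatter). Both are small and lie within the scatter, so neither gives a reason to expect a real shift or to favour a direction.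

The expected change is a 1.0-fold lower number from compound 3 to compound 4 (0.01 log units; within the scatter), which would be no step beyond the scatter. For compound 4 the estimated value is 1200 nM, with an expected range of 700 nM to 2000 nM.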

Compound 4, concentration for 50% growth inhibition: 1320 nM
The estimate for compound 4 lay 1.1-fold (0.04 log units) below the measured number; low and high end bracket the measured number.
By their numbers in this assay, from the lowest: compounds 1, 3, 4 and 2 (each within the scatter of the next).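

In this assay, among the compounds shown here, chloro in place of hydrogen on the aromatic carbon ortho to the trifluoromethyl group and para to a large group gives a 1.1-fold higher number from compound 3 to compound 4 (0.03 log units; within the scatter) and so marks no step beyond the scatter at this position, the first direct reading of a substituent there beside a lone trifluoromethyl group. With that chloro kept in place, trifluoromethyl in place of chloro on the neighbouring substituted carbon of the same aryl group gives a 1.1-fold lower number from compound 2 to compound 4 (0.03 log units; within the scatter) and so likewise shows no step beyond the scatter, which means that 4-chloro-3-(trifluoromethyl)phenyl joins the other aryl groups on the urea-type nitrogen in a single tight group of values. Nothing available explains why these steps are so small.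

What the compounds shown leave open is whether a group of a different kind on this carbon, such as an amine or a carboxylic acid in place of the chloro, would also stay within the scatter. They also leave open whether a change away from this aryl group, on the shared core, would move the number at all.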